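This account rests on a few compounds, and the source may have more. Where it says the series, first, only, none or still open, it means among the compounds named here.

Series notes. Compound 2 `CCN(Cc1ccsc1)C(=O)COc1ccc(C)cc1` is the reference point for the next step. Within the data shown here, in an assay on HEK293 cells for agonist activity at transient receptor potential cation channel subfamily M member 8 (Homo sapiens), read by fluorescence and calcium flux, with a stated time of 15 min (a higher number here means that more compound is needed for the effect, a lower number that less compound is needed), compound 2 gives 88 nM, which is the second highest of the three numbers measured so far. Compound 3 `CCN(Cc1cccs1)C(=O)COc1cc(C)ccc1O` gives 24 nM in this assay, a lower number than compound 2, and the gap lies beyond the scatter. Compound 1 `Cc1ccc(OCC(=O)N(CCO)Cc2cccs2)cc1` gives 900 nM in this assay, the highest number of the three, again beyond the scatter from compound 2. No pair among these three differs in a single place, so nothing in the measured set isolates the effect of changing the group on the amide-type nitrogen.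

Compound 4 `CCN(Cc1c[nH]nn1)C(=O)COc1ccc(C)cc1` is not yet measured. The change from compound 2 is 1H-1,2,3-triazol-4-yl in place of thiophen-3-yl on a saturated chain carbon bound to an amide-type nitrogen. Among the measured compounds shown here, no measured pair shows a comparable exchange, so the direction rests on the value of compound 2 alone. The expectation is an increase in the number beyond the scatter, with a step of a 6.8-fold higher number from compound 2 to compound 4 (0.83 log units; beyond the scatter). For compound 4 in this assay the estimate is 600 nM, with a range from 150 nM to 3000 nM, the wide range reflecting that nothing in the series constrains it closely.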

Compound 4, half-maximal effective concentration: 31100 nM
Beside the measured number, compound 4's estimate is 52-fold (1.71 log units) below it; the whole stated range lies below it.
By their numbers in this assay, from the lowest: compound 3; then compound 2; then compound 1; then compound 4.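

Among these compounds, at the saturated chain carbon bound to an amide-type nitrogen, 1H-1,2,3-triazol-4-yl in place of thiophen-3-yl gives a 350-fold higher number from compound 2 to compound 4 (2.55 log units; beyond the scatter) in this assay, a large change and the first single-place step. This position is therefore highly sensitive to which five-membered aromatic ring it carries, and the equal count of heavy atoms in the two rings shows that this count alone does not set the number. Nothing available explains the step, so which difference between the two rings carries it remains unassigned.

Open, from the compounds shown here alone, is whether 1-methyl-1H-1,2,3-triazol-4-yl, which lacks the ring hydrogen-bond donor, or furan-3-yl would follow compound 2 or compound 4. Also open, going by these compounds, is whether the exchange gives a step of similar size with a propyl group in place of ethyl on the amide-type nitrogen.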